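A few compounds are considered here, and "the series" means these few. Any claim that something is new, unique, unknown or untested is made for them only; others in the source may bear on it.

Working notes on the series. Compound 1 `COc1cc(-c2cc(/C=C/C(=O)c3ccc(N)cc3)[nH]n2)cc(OC)c1OC` carries an amino group on one aromatic ring; in a functional assay on OVCAR-5 cells (Homo sapiens) for cytotoxicity, read by sulforhodamine B assay, with a stated time of 48 h, tested at 0.01 uM (on this read-out lower numbers stand for a stronger effect and higher numbers for a weaker effect at the one concentration tested), compound 1 gives 90%. Compound 3 `COc1ccc(-c2cc(/C=C/C(=O)c3ccc(N)cc3)[nH]n2)cc1OC` gives 91%, and compound 2 `COc1ccc(-c2cc(/C=C/C(=O)c3ccc(OC)c(OC)c3)[nH]n2)cc1` gives 93%. Compound 1 holds the lowest of the three numbers, but both its nearest neighbour, compound 3, and its furthest, compound 2, lie within the scatter of it, so no order among the three can be read. Going by the values given here, the single one-place step measured so far, a number 1 percentage points higher from compound 1 to compound 3 (within the scatter), is flat as well.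

Compound 4 `COc1ccc(C(=O)/C=C/c2cc(-c3cc(OC)c(OC)c(OC)c3)n[nH]2)cc1` differs from compound 1 by methoxy in place of amino on an aromatic carbon. Among the compounds with values here, no measured step touches this position; the only step available, a number 1 percentage points higher from compound 1 to compound 3 (within the scatter), concerns a different methoxy group and stayed within the scatter, and compound 2, which carries methoxy groups and no amino group, gives 93%, again within the scatter of compound 1. No step beyond the scatter is therefore expected here. Compound 4 is estimated at 91%, with a range of 82% to 100%. The expected step is a number 1 percentage points higher from compound 1 to compound 4 (within the scatter).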

Compound 4, a percentage reported as activity, at one concentration (the size of the read-out at that concentration, not a potency): 99%
Estimate against measurement, compound 4: 8 percentage points below; low and high end bracket the measured number.
By their numbers in this assay, from the lowest: compounds 1, 3, 2 and 4 (each within the scatter of the next).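

Going by these compounds alone, at the place para to a large group, methoxy in place of amino gives a number 9 percentage points higher from compound 1 to compound 4 (within the scatter) in this assay, the first measured step at this position. Within the data shown here, the change from 4-aminophenyl to 4-methoxyphenyl therefore gives no readable order between these two compounds, although this step is larger than the only other one-place step. Nothing measured here accounts for the size of this step.

Open, as far as these compounds go, is whether a hydroxyl group, a carboxylic acid or a dimethylamino group at this same place would give a step beyond the scatter. Also open, from the compounds shown here alone, is whether amino and methoxy would separate at any other concentration, as the series is read here at a single one.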